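Removing the Methoxy Group from Compound 2: An Estimate

A few compounds are considered here, and "the series" means these few. Any claim that something is new, unique, unknown or untested is made for them only; others in the source may bear on it.

Measured compounds:
compound 1, `O=C(COc1ccc(C(=O)/C=C/c2ccc(F)c(F)c2)cc1)N[C@H]1CCOC1=O`: 21900 nM
compound 2, `COc1ccccc1/C=C/C(=O)c1ccc(OCC(=O)N[C@H]2CCOC2=O)cc1`: 7240 nM

Both compounds were tested in a functional assay on PC-3 cells (Homo sapiens) for antiproliferative activity, read by MTT assay, with a stated time of 72 h; on this read-out higher numbers stand for weaker inhibition and lower numbers for stronger inhibition. Within the data shown here, of the two numbers, compound 2 has the lower one, and its only neighbour is compound 1. Among the measured compounds shown here, the single measured step is a 3.0-fold lower number from compound 1 to compound 2 (0.48 log units; beyond the scatter), which shows that the group on the aryl ring at the end of the double-bonded chain can shift the number by a modest but real amount.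

Compound 3, `O=C(COc1ccc(C(=O)/C=C/c2ccccc2)cc1)N[C@H]1CCOC1=O`, differs from compound 2 in one place: hydrogen in place of methoxy on an aromatic carbon. For the measured compounds named here, no measured step removes this group outright; the one measured step only exchanges one ring substituent pattern for another, so it gives a direction for the size of such changes but not for this one in particular. With compound 1 as the only other point of reference, the number for compound 3 is expected to lie between those of compound 1 and compound 2, which means a step of a 1.7-fold higher number from compound 2 to compound 3 (0.22 log units; within the scatter) from compound 2 is estimated. Compound 3 is therefore expected to give about 12000 nM, with a range from 4000 nM to 36000 nM.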

Compound 3, half-maximal inhibitory concentration: 56800 nM
For compound 3 the middle estimate is 4.7-fold (0.68 log units) below the measured one; measured number above the stated range.
By their numbers in this assay, from the lowest: compound 2; then compound 1; then compound 3.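

In this assay, taking the methoxy group away gives the largest step among these three compounds: a 7.8-fold higher number from compound 2 to compound 3 (0.89 log units; beyond the scatter), so this aromatic carbon is a place where even a small group goes with a clear change in the number. The unsubstituted phenyl ring also compares poorly with the 3,4-difluorophenyl ring, with a 2.6-fold higher number from compound 1 to compound 3 (0.41 log units; beyond the scatter), so the two substituted rings shown both give stronger inhibition than phenyl, and neither of them goes against this pattern among the three compounds. No measured information here explains why removing either substituent raises the number.

The compounds shown leave open which part of the methoxy group goes with the lower number, its oxygen or its carbon, a question that a hydroxyl group or a methyl group on the same aromatic carbon could help to settle. They also leave open whether a larger group there, such as ethoxy, or a different kind of group, such as an amine, would lower the number further or raise it.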